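Working notes: thiophen-2-yl exchange on compound 1

The compounds below may be only part of what the source reports. "The series", "measured", "known", "first", "only" and "open" are said of these compounds alone.

compound 1 (`COc1cc(/C=C/C(=O)/C=C/c2cccs2)ccc1OCc1cn(CCOc2cc(=O)oc3ccccc23)nn1`) gives 71%
compound 2 (`COc1ccccc1/C=C/C(=O)/C=C/c1ccc(OCc2cn(CCCOc3cc(=O)oc4ccccc34)nn2)c(OC)c1`) gives 53%
compound 3 (`COc1cccc(/C=C/C(=O)/C=C/c2ccc(OCc3cn(CCCCOc4cc(=O)oc5ccccc45)nn3)c(OC)c2)c1`) gives 44%
compound 4 (`COc1cc(/C=C/C(=O)/C=C/c2cc(OC)c(OC)c(OC)c2)ccc1OCc1cn(CCOc2cc(=O)oc3ccccc23)nn1`) is not yet measured

In a functional assay on HCT-116 cells (Homo sapiens) for inhibition, read by sulforhodamine B assay, with a stated time of 48 h, tested at 50 uM (on this read-out higher numbers stand for more inhibition of growth at the one concentration tested and lower numbers for less inhibition of growth), compound 1 stands highest of the three, and both compound 2 and compound 3 lie below it beyond the scatter. Compound 4 differs from compound 1 on a double-bonded chain carbon bound to a double-bonded chain carbon: 3,4,5-trimethoxyphenyl in place of thiophen-2-yl on a double-bonded chain carbon bound to a double-bonded chain carbon. For the measured compounds named here, no measured pair differs in one place only, and this change has not been seen directly. Compound 1 already holds the top value of a small set, and a moderate fall is expected. The expected change is a number 13 percentage points lower from compound 1 to compound 4 (beyond the scatter) in this assay as estimated here. The estimate for compound 4 is 58% as the expected middle, with 38% to 78% as its expected range.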

Compound 4, percent growth inhibition at one concentration: 89%
Beside the measured number, compound 4's estimate is 31 percentage points below it, outside the stated range (above it).
By their numbers in this assay, from the lowest: compounds 3 and 2 (each within the scatter of the next); then compound 1; then compound 4.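

In this assay, for the compounds shown here, 3,4,5-trimethoxyphenyl in place of thiophen-2-yl gives a number 18 percentage points higher from compound 1 to compound 4 (beyond the scatter), the first step that can be read at a single place. This position on a double-bonded chain carbon bound to a double-bonded chain carbon therefore responds to the choice of aromatic ring, and a thiophen-2-yl group is not needed there for growth inhibition. No evidence on why this exchange raises the number is available.

On these data alone, whether the step comes from the methoxy groups or from the six-membered ring itself remains open. Plain phenyl or a ring bearing a dimethylamino group at this place would help to separate the two.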